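Adding a Methyl Group to the Core of Compound 3

This account rests on a few compounds, and the source may have more. Where it says the series, first, only, none or still open, it means among the compounds named here.

Three compounds sharing one core were tested in a functional assay on A-375 cells (Homo sapiens) for cytotoxicity, read by MTT assay, with a stated time of 72 h, tested at 10 uM; on this read-out higher numbers stand for more inhibition of growth at the one concentration tested and lower numbers for less inhibition of growth. Compound 1 `N/C(=N\NC(=S)N1CCCC1)c1ccc(F)cn1` gives 82.3%, compound 2 `N/C(=N\NC(=S)N1CCCCC1)c1ccccn1` gives 85.8%, and compound 3 `N/C(=N\NC(=S)N1CCCC1)c1ccccn1` gives 83.9%. The three numbers lie close together, and compound 3 sits within the usual scatter of both neighbours. Two single changes lead to compound 3: hydrogen in place of fluoro on an aromatic carbon, a number 1.6 percentage points higher from compound 1 to compound 3 (within the scatter), and pyrrolidin-1-yl in place of piperidin-1-yl on the thiocarbonyl carbon, a number 1.9 percentage points lower from compound 2 to compound 3 (within the scatter). Compound 4 `Cc1ccnc(/C(N)=N/NC(=S)N2CCCC2)c1` differs from compound 3 by methyl in place of hydrogen on an aromatic carbon. Because a number 1.6 percentage points higher from compound 1 to compound 3 (within the scatter) was small, a small ring change is again expected to leave this assay nearly unchanged, and the expected step is a number 0.1 percentage points higher from compound 3 to compound 4 (within the scatter). Compound 4 is therefore estimated at 84%, within a range from 70% to 92%.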

Compound 4, percent growth inhibition at one concentration: 86%
Compound 4: the middle estimate sits 2 percentage points below what was measured; the range from low to high includes it.
By their numbers in this assay, from the lowest: compounds 1, 3, 2 and 4 (each within the scatter of the next).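

Methyl in place of hydrogen on the aromatic carbon opposite the ring nitrogen gives, in this assay, a number 2.1 percentage points higher from compound 3 to compound 4 (within the scatter). This shows that a carbon group, and not only a hydrogen, can stand at this place without moving the number beyond the scatter. No measurement at hand explains the size of this step.

On these data alone, it remains open whether a longer chain such as butyl, or an amine or a carboxylic acid, would leave the number as little changed at this place. The compounds shown also leave open whether methyl would behave the same way on the other aromatic carbons.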